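From Bromo to Chloro: What Compound 4 Should Show

The source may hold more compounds than are shown below. What is called first, only, known or untested is meant among the compounds shown, and "the series" means these compounds.

Three analogues built on a shared core have been measured in a functional assay on DLD-1 cells (Homo sapiens) for cytotoxicity, read by colorimetric assay and MTT assay, with a stated time of 3 days, tested at 20 uM; a higher number here means a weaker effect of the compound at the concentration tested, a lower number a stronger effect. Compound 1 `COc1ccc(-n2cc(-c3ccccc3)c(-c3ccc4c(c3)NC(=O)CO4)n2)cc1` gives 35.6%. Compound 2 `Cc1ccccc1-n1cc(-c2ccccc2)c(-c2ccc3c(c2)NC(=O)CO3)n1` gives 62.9%, and compound 3 `O=C1COc2ccc(-c3nn(-c4ccc(Br)cc4)cc3-c3ccccc3)cc2N1` gives 54.2%. Among these three, compound 3 holds the second highest number: it sits a number 8.7 percentage points lower from compound 2 to compound 3 (within the scatter), and a number 18.6 percentage points higher from compound 1 to compound 3 (beyond the scatter), while a number 27.3 percentage points higher from compound 1 to compound 2 (beyond the scatter).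

Compound 4 `O=C1COc2ccc(-c3nn(-c4ccc(Cl)cc4)cc3-c3ccccc3)cc2N1` differs from compound 3 in one place: chloro in place of bromo on an aromatic carbon. Among the compounds with values here, of the measured steps, only the one from compound 1 to compound 3 touches this position, where bromo replaced methoxy, and the step from compound 2 to compound 3, which exchanged the whole substituted phenyl, stayed within the scatter. Within the data shown here, no measured step exchanges one halogen for another, so there is no direct guide. Among the measured compounds shown here, because a number 18.6 percentage points higher from compound 1 to compound 3 (beyond the scatter) was the only change at this carbon and was modest, the swap of bromo for chloro is expected to be smaller still, with no step beyond the scatter in this assay. Compound 4 is therefore estimated at 53%, between 40% and 67%, meaning an expected step of a number 1.2 percentage points lower from compound 3 to compound 4 (within the scatter).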

Compound 4, a percentage reported as activity, at one concentration (the size of the read-out at that concentration, not a potency): 47.1%
Estimate against measurement, compound 4: 5.9 percentage points above, and the stated range covers the measured number.
By their numbers in this assay, from the lowest: compound 1; then compounds 4, 3 and 2 (each within the scatter of the next, the first and the last beyond it).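

In this assay the exchange of one halogen for another on this aromatic carbon, para to a large group, gives a number 7.1 percentage points lower from compound 3 to compound 4 (within the scatter) and so does not separate 4-bromophenyl from 4-chlorophenyl. Chloro stays apart from methoxy as bromo did, with a number 11.5 percentage points higher from compound 1 to compound 4 (beyond the scatter) in that exchange, and the change to 4-chlorophenyl gives a number 15.8 percentage points lower from compound 2 to compound 4 (beyond the scatter) where the bromo analogue stayed within the scatter, though that contrast rests on two compounds that cannot be told apart. Nothing available here accounts for these steps.

From the compounds shown here alone, what an amine, a carboxylic acid or a longer alkoxy chain would give at this carbon stays open. Also open, going by these compounds, is how the unsubstituted phenyl on the shared core would respond to a group such as fluoro.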